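The source may hold more compounds than are shown below. What is called first, only, known or untested is meant among the compounds shown, and "the series" means these compounds.

Measured compounds:
compound 1, `CN(C(=O)NC(=O)c1cccc(C(F)(F)F)c1)c1nc(C(F)(F)F)c(C(=O)N/N=C/c2cccc(C(F)(F)F)c2)s1`: 5.79 ug/mL
compound 2, `Cc1nc(N(C)C(=O)NC(=O)c2c(F)cccc2F)sc1C(=O)N/N=C/c1ccc(C(F)(F)F)cc1`: a limit of the assay, > 100 ug/mL
compound 3, `Cc1nc(N(C)C(=O)NC(=O)c2c(F)cccc2F)sc1C(=O)N/N=C/c1ccccc1C(F)(F)F`: 1.11 ug/mL

All three were tested in a functional assay on HepG2 cells (Homo sapiens) for inhibition, read by MTT assay, with a stated time of 72 h; a lower number here means a stronger inhibitor, a higher number a weaker inhibitor. Compound 2 only reached the assay's limit, (the limit of > 100 ug/mL in this assay, at which 1 of the 3 values shown sits), so it gives no number. Of the two numbers, compound 1 has the higher one, and compound 3 sits lower by a gap beyond the scatter; compound 1 is thus the weaker of the two inhibitors with a number.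

Among the compounds with values here, the one measured step, an at least 90-fold lower number from compound 2 to compound 3 (1.95 log units; beyond the scatter), concerns the ring attached to the carbon with a double bond to nitrogen, at the far end of the shared core.

Compound 4, `CN(C(=O)NC(=O)c1ccccc1F)c1nc(C(F)(F)F)c(C(=O)N/N=C/c2cccc(C(F)(F)F)c2)s1`, differs from compound 1 at the other end: 2-fluorophenyl in place of 3-(trifluoromethyl)phenyl on a carbonyl carbon. Within the data shown here, no measured pair changes this ring alone, so the step just described does not bear on it; the pairs that do differ there also differ elsewhere and give no clean reading. Without evidence, the expected step, a 1.1-fold lower number from compound 1 to compound 4 (0.02 log units; within the scatter), is none beyond the scatter. Compound 4 is therefore estimated at 5.5 ug/mL, within a range from 1.5 ug/mL to 20 ug/mL.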

Compound 4, half-maximal inhibitory concentration: 20.3 ug/mL
Estimate against measurement, compound 4: 3.7-fold (0.57 log units) below, outside the stated range (above it).
By their numbers in this assay, from the lowest: compound 3; then compound 1; then compound 4. At a limit, above all of these: compound 2.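

Within the data shown here, until now, the only measured step concerned the ring attached to the carbon with a double bond to nitrogen; the change on the carbonyl carbon shows that the ring at the other end of the molecule also affects the result. In this assay, putting 2-fluorophenyl in place of 3-(trifluoromethyl)phenyl gives a 3.5-fold higher number from compound 1 to compound 4 (0.54 log units; beyond the scatter), a modest step but one beyond the scatter, so on the core of compound 1 the 3-(trifluoromethyl)phenyl ring gives the stronger inhibitor of this pair. This is a single pair on a single core, and nothing measured among the compounds shown accounts for the size or direction of the step.

The change alters both the substituent on the ring and its place there, so these compounds cannot separate the two effects; a 3-fluorophenyl or an unsubstituted phenyl on the same carbonyl carbon would help to do so. Also open, going by these compounds, are whether this step would hold on the core of compound 3, and how a ring carrying an amine or a carboxylic acid would behave at this position.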